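The compounds below may be only part of what the source reports. "The series", "measured", "known", "first", "only" and "open" are said of these compounds alone.

Measured so far in a functional assay on MCF7 cells (Homo sapiens) for inhibition, with a stated time of 48 h; on this read-out higher numbers stand for weaker inhibition and lower numbers for stronger inhibition:
- compound 1 `COc1cc(Sc2c[nH]c3ccc(Br)cc23)cc(OC)c1OC`: 43 nM
- compound 2 `COc1cc(Sc2c[nH]c3ccc(F)cc23)cc(OC)c1OC`: 160 nM
- compound 3 `COc1cc(Sc2c[nH]c3ccc([N+](=O)[O-])cc23)cc(OC)c1OC`: 560 nM

Compound 1 gives the lowest number of the three in this assay; the steps to both other compounds lie beyond the scatter, a 3.7-fold higher number from compound 1 to compound 2 (0.57 log units; beyond the scatter) and a 13-fold higher number from compound 1 to compound 3 (1.11 log units; beyond the scatter), so compound 1 stands as the strongest inhibitor of the set. Between the other two, a 3.5-fold higher number from compound 2 to compound 3 (0.54 log units; beyond the scatter).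

Compound 4 `COc1cc(Sc2c[nH]c3ccc(OCCO)cc23)cc(OC)c1OC` differs from compound 1 in one place: 2-hydroxyethoxy in place of bromo on an aromatic carbon. Going by the values given here, no measured step covers a change of this kind; the two steps that bear on it are those that replace the same bromo by another group, and both gave higher numbers, modest with fluoro and large with nitro. Among the compounds with values here, the new group is larger than either and carries a hydrogen-bond donor and two acceptors, which none of the measured groups do. On this basis a higher number than compound 1 is expected, with wide uncertainty, and the step from compound 1 to compound 4 is estimated as a 7.0-fold higher number from compound 1 to compound 4 (0.84 log units; beyond the scatter). For compound 4 in this assay the estimate is 300 nM, with a range from 80 nM to 1200 nM.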

Compound 4, half-maximal inhibitory concentration: 95 nM
Compound 4: the middle estimate sits 3.2-fold (0.50 log units) above what was measured; low and high end bracket the measured number.
By their numbers in this assay, from the lowest: compound 1; then compounds 4 and 2 (each within the scatter of the next); then compound 3.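

In this assay, this position takes a larger, hydrogen-bonding group with only a small loss: 2-hydroxyethoxy, with 4 heavy atoms, 1 hydrogen-bond donor and 2 hydrogen-bond acceptors, replaces bromo with a 2.2-fold higher number from compound 1 to compound 4 (0.34 log units; beyond the scatter). Against the other two groups, the same change gives a 5.9-fold lower number from compound 3 to compound 4 (0.77 log units; beyond the scatter) and a 1.7-fold lower number from compound 2 to compound 4 (0.23 log units; within the scatter), so among these four compounds a larger group does not bring a higher number, and this chain stands level with fluoro. No measurement at hand accounts for how well the chain is accepted here.

Open, from the compounds shown here alone, is whether the terminal hydroxyl contributes at all, a question that a methoxy group or a 2-methoxyethoxy chain would address. Also open, going by these compounds, is how far this position extends, which a 3-hydroxypropoxy chain or a 2-aminoethoxy chain would probe.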